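The source may report more compounds than this note shows. Statements on the series, on what has been measured and on what is new or still open speak of the compounds shown alone.

Measured so far in a functional assay on K562 cells (Homo sapiens) for inhibition, read by fluorescence, with a stated time of 72 h (on this read-out higher numbers stand for weaker inhibition of growth and lower numbers for stronger inhibition of growth), for this series:

- compound 1 `CC(C)=CCn1cnc2c(Nc3cccc(Cl)c3)nc(N[C@H]3CC[C@H](N)CC3)nc21` gives 3500 nM
- compound 2 `CCCCn1cnc2c(Nc3cccc(Cl)c3)nc(N[C@H]3CC[C@H](N)CC3)nc21` gives 2000 nM

Going by the values given here, compound 2 cannot be separated from the only other measured compound, and the two numbers give no ranking. Compound 3 `N[C@H]1CC[C@H](Nc2nc(Nc3cccc(Cl)c3)c3ncn(Cc4ccccc4)c3n2)CC1` differs from compound 2 in one place: phenyl in place of propyl on a saturated chain carbon bound to an aromatic nitrogen in the count of the change. The same change also reads as butyl to benzyl.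

Among the compounds with values here, only one measured step touches this place, and it is a 1.8-fold lower number from compound 1 to compound 2 (0.24 log units; within the scatter) in the series so far. Within the data shown here, that step exchanges one open chain for another, and no compound with a ring at this place has been measured, so it is a weak guide. On that basis, no step beyond the scatter is expected in this assay for this change, and no direction can be favoured. The estimated change is a 1.1-fold higher number from compound 2 to compound 3 (0.04 log units; within the scatter) on this evidence. Compound 3 is expected at about 2200 nM with an estimated range of 800 nM to 6000 nM given how little bears on it.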

Compound 3, concentration for 50% growth inhibition: 3000 nM
Beside the measured number, compound 3's estimate is 1.4-fold (0.13 log units) below it, within the range that was stated.
By their numbers in this assay, from the lowest: compounds 2, 3 and 1 (each within the scatter of the next).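

In this assay compound 3 puts the only ring seen so far on a saturated chain carbon bound to an aromatic nitrogen, and the change gives a 1.5-fold higher number from compound 2 to compound 3 (0.18 log units; within the scatter) when phenyl takes the place of propyl and a 1.2-fold lower number from compound 1 to compound 3 (0.07 log units; within the scatter) when phenyl takes the place of 2-methylprop-1-en-1-yl. Neither step separates compound 3 from the open-chain compounds, so this place now holds butyl, an open chain with a double bond and benzyl, on the shared core, with all three numbers inside the scatter of one another, and a six-membered aromatic ring of carbon only brings no step beyond the scatter here. No measurement at hand offers any explanation for these three numbers lying so close.

As far as these compounds go, whether a chain ending in an amine or a carboxylic acid at this place, or a longer chain, would give a step beyond the scatter remains open. Equally open, from the compounds shown here alone, is whether a pyridine ring in place of the phenyl, or a methoxy group on the phenyl of compound 3, would separate from compound 2 in this read-out.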